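Thiophene for Phenyl on Two Related Nucleoside Cores

The compounds below may be only part of what the source reports. "The series", "measured", "known", "first", "only" and "open" are said of these compounds alone.

Compound 1, `CSc1ncnc2c1c(-c1ccccc1)cn2[C@@H]1O[C@H](CO)[C@@H](O)[C@H]1O`, in an ADME assay on BJ cells (Homo sapiens), read by MTT assay, with a stated time of 72 h (a lower number here means a stronger inhibitor, a higher number a weaker inhibitor), gives > 100000 nM, which is a limit of the assay, not a number.
Compound 2, `Nc1nc(N)c2c(-c3ccccc3)cn([C@@H]3O[C@H](CO)[C@@H](O)[C@H]3O)c2n1`, gives in this assay > 100000 nM, again a limit of the assay.
Compound 3, `CSc1ncnc2c1c(-c1cccs1)cn2[C@@H]1O[C@H](CO)[C@@H](O)[C@H]1O`, gives in this assay 96900 nM.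

Going from compound 1 to compound 3 the change is thiophen-2-yl in place of phenyl on an aromatic carbon. The step is an at least 1.0-fold lower number from compound 1 to compound 3 (0.01 log units; that floor lies within the scatter), and it can be no more than a floor because of the limit of > 100000 nM in this assay, at which 2 of the 3 values shown sit. How the core of compound 1 differs from the core of compound 2 is not broken down here.

Compound 4, `Nc1nc(N)c2c(-c3cccs3)cn([C@@H]3O[C@H](CO)[C@@H](O)[C@H]3O)c2n1`, is not yet measured in this assay. From compound 2 to compound 4 the change is thiophen-2-yl in place of phenyl on an aromatic carbon, the same change as from compound 1 to compound 3, at the same place. Since that change gave a step within the scatter, and since compound 2 sits at a limit, the expected step is a number no higher from compound 2 to compound 4 (the limit leaves the size open), with the value likely again a limit. The estimate for compound 4 is 100000 nM, expected between 50000 nM and 200000 nM.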

Compound 4, half-maximal inhibitory concentration: > 100000 nM
Compound 4 gave a limit, no number (the forecaster's own chance of this, stated with the estimate: 65%); the middle value sits exactly at the limit.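

Compound 2 and compound 4 both sit at a limit of the assay, not at a number, so no step between them can be read: the limit of > 100000 nM in this assay, at which 3 of the 4 values shown sit.

The compounds shown leave open whether thiophen-2-yl in place of phenyl changes the number at all on the core of compound 2, and what the true values of compound 2 and compound 4 are.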